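Indole in place of thiophene: cytotoxicity at the limit

A few compounds are considered here, and "the series" means these few. Any claim that something is new, unique, unknown or untested is made for them only; others in the source may bear on it.

Measured compounds in an ADME assay on HEK293 cells (Homo sapiens) for cytotoxicity, read by CellTiter-Glo and resazurin assay, with a stated time of 72 h; a higher number here means that more compound is needed for the effect, a lower number that less compound is needed:
- compound 1 `CC(C)N(Cc1cccc(OCCCCCC(=O)O)c1)C(=O)c1ccc(-c2ccoc2)cc1`: > 26000 nM
- compound 2 `CC(C)N(Cc1cccc(OCCCCCC(=O)O)c1)C(=O)c1ccc(-c2ccsc2)cc1`: > 26000 nM
- compound 3 `CC(C)N(Cc1cccc(OCCCCCC(=O)O)c1)C(=O)c1ccc(-c2cc3ccccc3n2S(=O)(=O)c2ccccc2)cc1`: > 26000 nM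

All three share one core, a branched amide with an acid-tipped chain on one side and a biaryl on the other. In this assay compound 1 shows only a limit, > 26000 nM, and not a number. Compound 2 likewise returns only the limit of > 26000 nM in this assay. Compound 3, with its sulfonyl-protected indole, also sits at the limit of > 26000 nM. Because of the limit of > 26000 nM in this assay, at which 3 of the 3 values shown sit, no real difference between them can be read; the move a step that the two limits leave unreadable from compound 1 to compound 2 is hidden behind the two limits.

Compound 4 `CC(C)N(Cc1cccc(OCCCCCC(=O)O)c1)C(=O)c1ccc(-c2c[nH]c3ccccc23)cc1` is not yet measured. It differs from compound 2 by 1H-indol-3-yl in place of thiophen-3-yl on an aromatic carbon. Compound 3, which carries a related bicyclic group on the same carbon, gives no sign of toxicity, so no step beyond the scatter is expected in this assay.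

For compound 4 the expectation is a value near the limit, estimated at 30000 nM within 15000 nM to 60000 nM, implying an estimated step that the limit leaves unreadable from compound 2 to compound 4 that most likely again reads as a limit.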

Compound 4, half-maximal effective concentration: > 26000 nM
Compound 4: a limit, no number; the forecaster's own chance of this, stated with the estimate: 80%; the middle value does not contradict the limit.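

Compound 4 gives only a limit of > 26000 nM and not a number. Among the compounds shown here, no step among compound 1, compound 2 and compound 4 can be read, because all of their values sit at the same limit: the limit of > 26000 nM in this assay, at which 4 of the 4 values shown sit.

The compounds shown leave open at what concentration, if any, these four compounds would begin to harm the cells.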